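This account rests on a few compounds, and the source may have more. Where it says the series, first, only, none or still open, it means among the compounds named here.

Compound 2 `CC1CCN(C2CCN(S(=O)(=O)c3ccccc3Br)CC2)CC1` gives the lowest of the two numbers seen so far in a functional assay on DLD-1 cells (Homo sapiens) for antiproliferative activity, read by CellTiter-Glo, with a stated time of 72 h; a lower number here means a stronger inhibitor, a higher number a weaker inhibitor: compound 2 reaches 3 nM, while compound 1 `CC1CCN(C2CCN(S(=O)(=O)c3cccc(N)c3)CC2)CC1` gives 3400 nM. Going by the values given here, the only measured step changed the group on the sulfonyl sulfur, and it was large: a 1100-fold lower number from compound 1 to compound 2 (3.05 log units; beyond the scatter). Compound 3 `CC1CCN(C2CCN(S(=O)(=O)c3nccn3C)CC2)CC1` again changes that group: 1-methyl-1H-imidazol-2-yl in place of 2-bromophenyl on a sulfonyl sulfur. Among the compounds with values here, since the one known step at this position was so large, a sizeable move is expected here too, most likely towards a higher number, so compound 3 is expected to give 300 nM, within 30 nM to 3000 nM, which would mean an expected step of a 100-fold higher number from compound 2 to compound 3 (2.00 log units; beyond the scatter).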

Compound 3, half-maximal inhibitory concentration: > 5000 nM
Compound 3 gave a limit, no number (the forecaster's own chance of this, stated with the estimate: 5%); middle value at least 16-fold (1.22 log units) from the limit.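

The value of compound 3 is a limit of the assay and not a number: the limit of > 5000 nM in this assay, at which 1 of the 3 values shown sits. Even so, the step is clear, an at least 1600-fold higher number from compound 2 to compound 3 (3.22 log units; beyond the scatter), so on this sulfonyl sulfur an aromatic ring alone does not preserve the low number of compound 2. The other comparison, an at least 1.4-fold higher number from compound 1 to compound 3 (0.16 log units; that floor lies within the scatter), sets no order between those two compounds. The compounds shown leave open how much of the low number depends on the bromine itself. A plain phenyl, or a phenyl carrying chlorine or methyl in place of bromine, would help to separate the contribution of the ring from that of the bromine.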